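The compounds below may be only part of what the source reports. "The series", "measured", "known", "first", "only" and "open" are said of these compounds alone.

Measured so far:
- compound 1 `Cc1cc2c(cc1C)C(Cl)=C(c1nnc(-c3ccccc3)o1)CCC2`: 1960 nM
- compound 2 `Cc1cc2c(cc1C)C(Cl)=C(c1nnc(-c3cccc(I)c3)o1)CCC2`: 2780 nM

In a functional assay on A549 cells (Homo sapiens) for antiproliferative activity, read by sulforhodamine B assay, with a stated time of 48 h (on this read-out higher numbers stand for weaker inhibition of growth and lower numbers for stronger inhibition of growth), compound 2 gives 2780 nM. Going by the values given here, that number lies within the scatter of the only other measured compound, compound 1, which gives 1960 nM. The next compound, compound 3 `Cc1cc2c(cc1C)C(Cl)=C(c1nnc(-c3cccc(C(F)(F)F)c3)o1)CCC2`, differs from compound 2 by one exchange: trifluoromethyl in place of iodo on an aromatic carbon. In words, this is trifluoromethyl in place of iodo on an aromatic carbon, meta to a large group.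

Among the compounds with values here, no measured compound carries trifluoromethyl, so the data offer no direct comparison for the entering group. Within the data shown here, the one measured step that bears on the change is a 1.4-fold higher number from compound 1 to compound 2 (0.15 log units; within the scatter), where iodo took the place of hydrogen on an aromatic carbon. On the evidence of that small step, no change beyond the scatter is expected in this assay, and no direction is firmly favoured. The expected step, which is only an estimate, is a 1.2-fold lower number from compound 2 to compound 3 (0.06 log units; within the scatter). The estimated value for compound 3 is 2400 nM, with an expected range from 1200 nM to 4800 nM.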

Compound 3, concentration for 50% growth inhibition: 1970 nM
Compound 3: the middle estimate sits 1.2-fold (0.09 log units) above what was measured; measured number inside the range.
By their numbers in this assay, from the lowest: compounds 1, 3 and 2 (each within the scatter of the next).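

In this assay, trifluoromethyl in place of iodo gives a 1.4-fold lower number from compound 2 to compound 3 (0.15 log units; within the scatter), and trifluoromethyl in place of hydrogen gives a 1.0-fold higher number from compound 1 to compound 3 (0.00 log units; within the scatter). Going by these compounds alone, this position, on an aromatic carbon meta to a large group, has now carried hydrogen, iodo and trifluoromethyl, and all three compounds read within the scatter of one another, even though the exchange from iodo to trifluoromethyl goes from one heavy atom to four; across these three compounds, then, the read-out does not separate the groups, and no compound goes against that flat picture. Nothing measured here gives a reason for this result.

Iodo and trifluoromethyl both carry no hydrogen-bond donors or acceptors and no net charge, so the compounds shown leave open how an amine, a carboxylic acid or a hydroxyl group would read at this same carbon. Also open, going by these compounds, is whether a longer chain or a second ring at this place would stay within the scatter of compound 1, and whether the same flat picture holds elsewhere on the six-membered aromatic ring.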